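The source may report more compounds than this note shows. Statements on the series, on what has been measured and on what is new or still open speak of the compounds shown alone.

Measured so far:
- compound 1, `COc1ccc(-c2cn(-c3ccc(O)c(C(=O)Nc4cccc(C(F)(F)F)c4)c3)nn2)cc1`: 9%
- compound 2, `O=C(OCCCc1ccccc1)c1cc(-n2cc(-c3cc(O)ccc3O)nn2)ccc1O`: 39%
- compound 3, `COc1ccccc1-c1cn(-c2ccc(O)c(C(=O)OCCCc3ccccc3)c2)nn1`: 7%

In a functional assay on HCT-116 cells (Homo sapiens) for inhibition, read by MTT assay, with a stated time of 2 days, tested at 10 uM (on this read-out lower numbers stand for less inhibition and higher numbers for more inhibition at the one concentration tested (going by the name of the read-out)), compound 3 gives the lowest of the three numbers; compound 1 is within the scatter of it, while compound 2 stands well above both. For the measured compounds named here, the one single-place step seen, a number 32 percentage points lower from compound 2 to compound 3 (beyond the scatter), shows that the group on the five-membered ring matters strongly in this set. Compound 4, `COc1ccc(-c2cn(-c3ccc(O)c(C(=O)OCCCc4ccccc4)c3)nn2)cc1`, differs from compound 3 by 4-methoxyphenyl in place of 2-methoxyphenyl on an aromatic carbon. Going by the values given here, no measured step covers this exact change; the closest guide is compound 1, which also carries a 4-methoxyphenyl and sits within the scatter of compound 3. Compound 4 is therefore expected to stay close, with a step of a number 2 percentage points higher from compound 3 to compound 4 (within the scatter), so its estimate is 9%, ranging from 0% to 22%.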

Compound 4, a percentage reported as inhibition, at one concentration (the size of the read-out at that concentration, not a potency): 12%
For compound 4 the middle estimate is 3 percentage points below the measured one, and the stated range covers the measured number.
By their numbers in this assay, from the lowest: compounds 3, 1 and 4 (each within the scatter of the next); then compound 2.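

Changing 2-methoxyphenyl to 4-methoxyphenyl on this carbon of the five-membered ring gives a number 5 percentage points higher from compound 3 to compound 4 (within the scatter) in this assay so the two methoxyphenyl groups cannot be told apart here. Replacing 2,5-dihydroxyphenyl with 4-methoxyphenyl gives a number 27 percentage points lower from compound 2 to compound 4 (beyond the scatter) so the drop seen with 2-methoxyphenyl is not confined to that one group. Exchanging (3-(trifluoromethyl)phenyl)amino for 3-phenylpropoxy on the carbonyl carbon gives a number 3 percentage points higher from compound 1 to compound 4 (within the scatter) and so shows no clear effect with 4-methoxyphenyl in place. From the compounds shown here alone, how 4-hydroxyphenyl or 4-aminophenyl would read at this carbon remains open. No supporting measurement bears on these results.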